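Carbonyl substituent swap: outlook for compound 3

The source may hold more compounds than are shown below. What is called first, only, known or untested is meant among the compounds shown, and "the series" means these compounds.

In a functional assay on MGC-803 cells (Homo sapiens) for inhibition, read by MTT assay, with a stated time of 48 h (a higher number here means a weaker inhibitor, a lower number a stronger inhibitor), compound 1 `C/C=C/C=C/C(=O)N(Cc1ccc(OC)c(O)c1)c1cc(OC)c(OC)c(OC)c1` gives 140 nM and compound 2 `COc1ccc(CN(C(=O)CO)c2cc(OC)c(OC)c(OC)c2)cc1O` gives 160 nM. Among the measured compounds shown here, these two numbers lie within the scatter of each other, so compound 2 stands level with the only other measured member of the series.

Compound 3 `C/C=C/C(=O)N(Cc1ccc(OC)c(O)c1)c1cc(OC)c(OC)c(OC)c1` has prop-1-en-1-yl in place of hydroxymethyl on a carbonyl carbon. For the measured compounds named here, one measured step bears on this, at the same carbonyl carbon: a 1.1-fold higher number from compound 1 to compound 2 (0.06 log units; within the scatter). That step exchanged penta-1,3-dien-1-yl for hydroxymethyl and stayed within the scatter. Going by the values given here, with only this one step, the evidence is thin, and the range is kept wide. No step beyond the scatter is expected in this assay, in either direction. The estimated step is a 1.1-fold lower number from compound 2 to compound 3 (0.03 log units; within the scatter). The expected value for compound 3 is 150 nM, with an estimated range of 70 nM to 320 nM.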

Compound 3, half-maximal inhibitory concentration: 27 nM
Beside the measured number, compound 3's estimate is 5.6-fold (0.74 log units) above it; measured number below the stated range.
By their numbers in this assay, from the lowest: compound 3; then compounds 1 and 2 (each within the scatter of the next).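

In this assay, among the compounds shown here, the substituent on this carbonyl carbon clearly matters, which compound 1 and compound 2 alone, standing level, gave no sign of: prop-1-en-1-yl in place of hydroxymethyl gives a 5.9-fold lower number from compound 2 to compound 3 (0.77 log units; beyond the scatter) and marks the first step beyond the scatter. The change from penta-1,3-dien-1-yl to prop-1-en-1-yl gives a 5.2-fold lower number from compound 1 to compound 3 (0.71 log units; beyond the scatter) as well, so an unsaturated chain on this carbon does not by itself set the number, and compound 1 goes against any such reading. Nothing available accounts for the gain at compound 3.

Still open, as far as these compounds go, is whether the double bond of prop-1-en-1-yl is needed, which a saturated propyl chain on the same carbonyl carbon would test. From the compounds shown here alone, how a smaller methyl group or a chain ending in an amine would compare is also open.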